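From piperidin-1-yl to piperazin-1-yl on the highest-number compound

This account rests on a few compounds, and the source may have more. Where it says the series, first, only, none or still open, it means among the compounds named here.

Compound 1 `O=C(/C=C/c1ccc([N+](=O)[O-])o1)c1ccc(I)cc1` gives 2100 nM
Compound 2 `O=C(/C=C/c1ccc([N+](=O)[O-])o1)c1ccc(-n2ccnc2)cc1` gives 3500 nM
Compound 3 `O=C(/C=C/c1ccc([N+](=O)[O-])o1)c1ccc(N2CCCCC2)cc1` gives 48700 nM
Compound 4 `O=C(/C=C/c1ccc([N+](=O)[O-])o1)c1ccc(N2CCNCC2)cc1` has not yet been measured

These numbers come from a functional assay on C6 cells (Rattus norvegicus) for inhibition, read by sulforhodamine B assay, with a stated time of 72 h (on this read-out lower numbers stand for an effect already at smaller amounts and higher numbers for an effect only at larger amounts of compound), and the compounds share one core and differ in a single group. Compound 3 has the highest number of the three, so it needs the largest amount to show its effect.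

Compound 4 differs from it by one change, (piperazin-1-yl in place of piperidin-1-yl on an aromatic carbon), with piperazin-1-yl in place of piperidin-1-yl on an aromatic carbon. For the measured compounds named here, no measured step makes this exact exchange. The closest evidence comes from two large steps into piperidin-1-yl, a 23-fold higher number from compound 1 to compound 3 (1.37 log units; beyond the scatter) and a 14-fold higher number from compound 2 to compound 3 (1.14 log units; beyond the scatter), both upward. By contrast, a 1.7-fold higher number from compound 1 to compound 2 (0.22 log units; within the scatter) is a step within the scatter. Going by the values given here, three compounds are a thin basis, but piperidin-1-yl is the only group here tied to a high number. Leaving it may lower the number, yet the entering group is also a six-membered non-aromatic ring, so only part of that gap is expected to close in this assay.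

The expected outcome is a 3.2-fold lower number from compound 3 to compound 4 (0.51 log units; beyond the scatter), a moderate drop with real uncertainty. For compound 4 the estimated value is 15000 nM, with an expected range from 3500 nM to 60000 nM as its likely bounds.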

Compound 4, half-maximal effective concentration: 1500 nM
Compound 4: the middle estimate sits 10-fold (1.00 log units) above what was measured, and the stated range ends above it.
By their numbers in this assay, from the lowest: compounds 4, 1 and 2 (each within the scatter of the next, the first and the last beyond it); then compound 3.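

In this assay the exchange of piperidin-1-yl for piperazin-1-yl gives a 32-fold lower number from compound 3 to compound 4 (1.51 log units; beyond the scatter) even though both groups are six-membered non-aromatic rings with the same count of heavy atoms, so the high number of compound 3 cannot be tied to having such a ring at this place. The change is a swap of one ring carbon for a nitrogen, which also brings a hydrogen-bond donor, and that small edit is enough to bring the number down to the level of the other groups: a 1.4-fold lower number from compound 1 to compound 4 (0.15 log units; within the scatter) stays within the scatter, while a 2.3-fold lower number from compound 2 to compound 4 (0.37 log units; beyond the scatter) is a modest step beyond it. Among these four compounds, piperidin-1-yl is now the only group that stands apart, and no measurement here explains why.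

From the compounds shown here alone, what remains open is which feature of the piperazin-1-yl ring matters, a question that morpholin-4-yl, with a ring oxygen in place of that nitrogen, or 4-methylpiperazin-1-yl, with a methyl on it, could help to separate. An open-chain amine such as dimethylamino at the same place would show whether a ring is needed at all.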